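Exchanging One Aryl Linker for Another in a Cytotoxicity Series

This account rests on a few compounds, and the source may have more. Where it says the series, first, only, none or still open, it means among the compounds named here.

Measured compounds:
compound 1 `CC1(Cc2ccccc2)CC(S(=O)(=O)c2ccccc2)=C(c2ccc(/C(N)=N/O)cc2)O1` gives 94600 nM
compound 2 `CC1(Cc2ccccc2)CC(S(=O)(=O)c2ccc(Nc3ccc(/C(N)=N/O)cc3)cc2)=C(c2ccc(/C(N)=N/O)cc2)O1` gives 47600 nM
compound 3 `CC1(Cc2ccccc2)CC(S(=O)(=O)c2ccc(Nc3ccccc3/C(N)=N/O)cc2)=C(c2ccc(/C(N)=N/O)cc2)O1` gives 48400 nM

These three share one core and were tested in an ADME assay on THP-1 cells (Homo sapiens) for cytotoxicity, read by flow cytometry, with a stated time of 72 h; a higher number here means a weaker inhibitor, a lower number a stronger inhibitor. Compound 3 stands second highest of the three numbers; its nearest neighbour is compound 2, and the gap to compound 1 is also within the scatter, so the three are not separated by this assay.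

Compound 4 `CC1(Cc2ccccc2)CC(S(=O)(=O)c2ccc(/C=C/c3ccc(/C(N)=N/O)cc3)cc2)=C(c2ccc(/C(N)=N/O)cc2)O1` is not yet measured. It differs from compound 3 in one place: a group of 12 heavy atoms (9 carbon, 2 nitrogen, 1 oxygen; one six-membered aromatic ring of carbon only) in place of a group of 11 heavy atoms (7 carbon, 3 nitrogen, 1 oxygen; one six-membered aromatic ring of carbon only), on an aromatic carbon. The steps already seen are small: a 2.0-fold lower number from compound 1 to compound 2 (0.30 log units; within the scatter), a 2.0-fold lower number from compound 1 to compound 3 (0.29 log units; within the scatter), and a 1.0-fold higher number from compound 2 to compound 3 (0.01 log units; within the scatter). Adding a large aryl-bearing group, or swapping one such group for another, has so far left the number where it was.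

On that basis no step beyond the scatter is expected from compound 3 to compound 4: a 1.0-fold higher number from compound 3 to compound 4 (0.01 log units; within the scatter). Compound 4 is therefore estimated at 50000 nM, with a range from 22000 nM to 110000 nM.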

Compound 4, half-maximal inhibitory concentration: > 50000 nM
Compound 4: only a limit was reported (the forecaster's own chance of this, stated with the estimate: 10%); the middle value sits exactly at the limit.
By their numbers in this assay, from the lowest: compounds 2, 3 and 1 (each within the scatter of the next).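

In this assay compound 4 gives > 50000 nM, which is a limit of the assay and not a number. Swapping the group on this aromatic carbon, para to a large group, for one with 2 double bonds outside aromatic rings gives an at least 1.0-fold higher number from compound 3 to compound 4 (0.01 log units; that floor lies within the scatter) and an at least 1.0-fold higher number from compound 2 to compound 4 (0.02 log units; that floor lies within the scatter), while the step from compound 1 cannot be read. Unlike the earlier steps, these have no upper end, so this change may leave the number where it was or may raise it by an unknown amount, and the reading rests on a limit: the limit of > 50000 nM in this assay, at which 1 of the 4 values shown sits.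

On these data alone, the true value of compound 4 stays open, and with it the size of this change. Also open, as far as these compounds go, is whether a group without the aromatic ring, such as an amine or a carboxylic acid on this aromatic carbon, would give a step beyond the scatter.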